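The source may report more compounds than this note shows. Statements on the series, on what has been measured and on what is new or still open speak of the compounds shown alone.

Measured compounds:
Compound 1, `COc1ccc(Sc2nc3cc(N)cc(N)c3nc2-c2ccccc2)cc1`, in a functional assay on OVCAR-5 cells (Homo sapiens) for inhibition, read by sulforhodamine B assay, with a stated time of 48 h; a lower number here means a stronger inhibitor of growth, a higher number a weaker inhibitor of growth: < 100000 nM
Compound 2, `Nc1cc(N)c2nc(-c3ccccc3)c(Oc3ccc(F)cc3)nc2c1`, in this assay: 47900 nM

In this assay compound 1 gives < 100000 nM, which is a limit of the assay and not a number. Within the data shown here, compound 2 gives 47900 nM in this assay, the only number in the set, so it stands alone and cannot be ranked against compound 1. The step that the limit leaves unreadable from compound 1 to compound 2 is unreadable because of the limit of < 100000 nM in this assay, at which 1 of the 2 values shown sits.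

Compound 3, `Nc1cc(N)c2nc(-c3ccccc3)c(Sc3ccc(F)cc3)nc2c1`, has not yet been measured. It differs from compound 2 by (4-fluorophenyl)sulfanyl in place of 4-fluorophenoxy on an aromatic carbon. Among the measured compounds shown here, the single measured step is the only one that touches this position, and it also swaps the methoxy for a fluorine; its size is hidden by the limit, so it gives no readable guide to the direction or size of the change from an oxygen linker to a sulfur linker. Compound 3 is therefore expected to sit near compound 2, with a step of a 1.1-fold lower number from compound 2 to compound 3 (0.03 log units; within the scatter) that is not expected to go beyond the scatter. The estimate for compound 3 in this assay is 45000 nM, with a range from 15000 nM to 100000 nM.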

Compound 3, concentration for total growth inhibition: 45700 nM
Beside the measured number, compound 3's estimate is 1.0-fold (0.01 log units) below it, and the stated range covers the measured number.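

In this assay, (4-fluorophenyl)sulfanyl in place of 4-fluorophenoxy gives a 1.0-fold lower number from compound 2 to compound 3 (0.02 log units; within the scatter), so with the rest of the molecule held the same, the oxygen and the sulfur linker cannot be told apart in this read-out. Among these compounds, this is the first readable step at this position, and the first comparison that separates the linker atom from the exchange of methoxy for fluoro, which the step from the earlier pair had mixed together. The two steps that start from compound 1 cannot be read, so fluoro in place of methoxy on the sulfur-linked ring has no size, because of this: the limit of < 100000 nM in this assay, at which 1 of the 3 values shown sits.

The compounds shown leave open whether another linker, such as an amine or a methylene, would read the same as oxygen and sulfur at this position, and how a chloro group or a carboxylic acid would read in place of the fluoro group. They also leave open what happens when the phenyl group on the shared core, present in all three compounds, gives way to a small group such as methyl.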